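A few compounds are considered here, and "the series" means these few. Any claim that something is new, unique, unknown or untested is made for them only; others in the source may bear on it.

In a functional assay on the whole organism with Rattus norvegicus as the target (a lower number here means that less compound is needed, a higher number that more compound is needed for the effect), compound 3 `N=c1sc2cc(OC(F)(F)F)ccc2n1CCSc1ccccc1` gives 4.5 mg/kg, within the scatter of compound 1 `C=CCn1c(=N)sc2cc(OC(F)(F)F)ccc21` at 7 mg/kg, while compound 2 `CSCCn1c(=N)sc2cc(OC(F)(F)F)ccc21` gives 1 mg/kg. Compound 4 `CSCCCn1c(=N)sc2cc(OC(F)(F)F)ccc21` differs from compound 3 in one place: (methylsulfanyl)methyl in place of phenylsulfanyl on a saturated chain carbon, two bonds along the chain from an aromatic nitrogen. In words, (methylsulfanyl)methyl stands in place of phenylsulfanyl on a saturated chain carbon, two bonds along the chain from an aromatic nitrogen. The closest measured evidence is a 4.5-fold higher number from compound 2 to compound 3 (0.65 log units; beyond the scatter), where phenyl in place of methyl on a sulfur gave a higher number. Among the measured compounds shown here, compound 4 also has methyl on its sulfur, but its chain differs, and no measured step isolates that change. A modest move to a lower number is therefore expected, estimated as a 2.3-fold lower number from compound 3 to compound 4 (0.35 log units; beyond the scatter). Compound 4 is expected at 2 mg/kg, within an estimated range of 0.7 mg/kg to 6 mg/kg.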

Compound 4, dose for half-maximal effect: 4.2 mg/kg
Compound 4: the middle estimate sits 2.1-fold (0.32 log units) below what was measured; the measured number falls inside the stated range.
By their numbers in this assay, from the lowest: compound 2; then compounds 4, 3 and 1 (each within the scatter of the next).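

Replacing phenylsulfanyl with (methylsulfanyl)methyl at this place leaves the number almost unchanged, with a 1.1-fold lower number from compound 3 to compound 4 (0.03 log units; within the scatter), so a sulfur chain without the aromatic ring does not by that alone give a low number. The low number is also lost when (methylsulfanyl)methyl replaces methylsulfanyl, with a 4.2-fold higher number from compound 2 to compound 4 (0.62 log units; beyond the scatter). Replacing vinyl with 2-(methylsulfanyl)ethyl gives a 1.7-fold lower number from compound 1 to compound 4 (0.22 log units; within the scatter), so that change shows no clear gain.

Nothing shown explains these numbers. From the compounds shown here alone, whether an amine or a hydroxyl group in place of methylsulfanyl would keep the low number of compound 2 stays open.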